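This account rests on a few compounds, and the source may have more. Where it says the series, first, only, none or still open, it means among the compounds named here.

Compound 1, with the structure `C[C@@H](O)[C@H](NC(=O)CN(c1nc(Cl)nc2[nH]cnc12)C1CC1)C(=O)O`, was tested in a functional assay on the whole organism (Tail, strain ICR) with Mus musculus as the target, in the tail flick test, with a stated time of 90 min, at a dose of 25 umol/kg by the oral route (on this read-out higher numbers stand for a stronger effect at the one dose given and lower numbers for a weaker effect), where compound 1 gives 35.9%. Two related compounds were measured alongside it. Compound 2, `O=C(CN(c1nc(Cl)nc2[nH]cnc12)C1CC1)NCC(=O)OCc1ccccc1`, gives 27.2% in this assay, and compound 3, `CSCC[C@H](NC(=O)CN(c1ncnc2c1ncn2C1CCCCO1)C1CC1)C(=O)OCc1ccccc1`, gives 42.7%. The three numbers sit close together: compound 1 lies between the other two, and its gaps to both compound 2 and compound 3 fall within the usual scatter of this kind of measurement, so none of the three can be told apart from the others with confidence.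

The new compound, compound 4, has the structure `N=C(N)NCCC[C@H](NC(=O)CN(c1nc(Cl)nc2[nH]cnc12)C1CC1)C(=O)O`. It differs from compound 1 in one place: a group of 7 heavy atoms (4 carbon, 3 nitrogen; no ring) in place of a group of 3 heavy atoms (2 carbon, 1 oxygen; no ring), on a saturated chain carbon bound to an amide-type nitrogen and a carbonyl carbon. The shared core and the rest of the chain stay the same.

Among the measured compounds shown here, no step between measured compounds bears on this change, so its size has to be guessed. The three measured compounds, though they differ in several places, all give numbers within the scatter of one another. Compound 4 is therefore expected to give about 38%, in a range from 20% to 56%. The change this estimate means, a number 2.1 percentage points higher from compound 1 to compound 4 (within the scatter), is expected to stay within the scatter.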

Compound 4, a percentage reported as activity, at one dose (the size of the read-out at that dose, not a potency): 27.6%
The estimate for compound 4 lay 10.4 percentage points above the measured number; the measured number falls inside the stated range.
By their numbers in this assay, from the lowest: compounds 2, 4, 1 and 3 (each within the scatter of the next, the first and the last beyond it).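

In this assay, among the compounds shown here, exchanging 1-hydroxyethyl for the group of 7 heavy atoms (4 carbon, 3 nitrogen) gives a number 8.3 percentage points lower from compound 1 to compound 4 (within the scatter), the first comparison of compounds that differ in one place. On this step, compound 1 and compound 4 cannot be told apart at the one dose given, even though the entering group is the larger one and has 3 hydrogen-bond donors where the leaving group has 1. Nothing measured here offers an explanation for this result.

Still open, on these data alone, is whether a methyl group, a short chain ending in a primary amine, or a carboxylic acid on this saturated chain carbon would also stay within the scatter of compound 1. This single step also leaves open whether the same exchange would give a similar result on a different core or ester.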